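Ester variation on the shared core: towards compound 3

The compounds below may be only part of what the source reports. "The series", "measured", "known", "first", "only" and "open" are said of these compounds alone.

Compound 1 `CCOC(=O)C(=O)Nc1cccccc1=O` and compound 2 `CC(C)(C)OC(=O)C(=O)Nc1cccccc1=O` share one core and differ only in the ester group on an oxygen next to a carbonyl group. In a functional assay on the whole organism (strain Sprague-Dawley CD) for inhibition, with Rattus norvegicus as the target, read by paw edema, at a dose of 30 mg/kg by the intraperitoneal route (a lower number here means a weaker effect, a higher number a stronger effect of the compound at the dose given), compound 1 gives 84% and compound 2 gives 79%. Among the measured compounds shown here, the only measured step, a number 5 percentage points lower from compound 1 to compound 2 (within the scatter), is no change beyond the scatter. On the two numbers shown, compound 2 and compound 1 sit within the scatter of each other, so neither stands apart.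

Compound 3 `O=C(O)COC(=O)C(=O)Nc1cccccc1=O` differs from compound 2 by carboxymethyl in place of tert-butyl on an oxygen next to a carbonyl group. The step that bears on this change is a number 5 percentage points lower from compound 1 to compound 2 (within the scatter), which exchanged one ester group for another and stayed within the scatter. For the measured compounds named here, no measured step introduces a carboxymethyl group, and neither measured compound carries a hydrogen-bond donor in the ester part, so the series gives no direct guide. The expected step in this assay is a number 9 percentage points lower from compound 2 to compound 3 (within the scatter), a modest loss that may not exceed the scatter, with a wide range. Compound 3 is therefore estimated at 70%, between 48% and 90%.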

Compound 3, a percentage reported as inhibition, in the whole organism at one dose (the size of the read-out at that dose, not a potency): 93%
Compound 3: middle estimate off by 23 percentage points, on the low side; the whole stated range lies below it.
By their numbers in this assay, from the lowest: compounds 2, 1 and 3 (each within the scatter of the next, the first and the last beyond it).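

In this assay, the ester position, on an oxygen next to a carbonyl group, now shows its first step beyond the scatter: a number 14 percentage points higher from compound 2 to compound 3 (beyond the scatter), with carboxymethyl in place of tert-butyl and a hydrogen-bond donor entering where the earlier esters carry none. Against the ethyl ester the reading is different, a number 9 percentage points higher from compound 1 to compound 3 (within the scatter), so carboxy in place of methyl on a saturated chain carbon bound to an oxygen next to a carbonyl group does not set compound 3 apart from compound 1, and only the pair of compound 2 and compound 3 separates. The data shown hold no measurement that could explain the step beyond the scatter.

From the compounds shown here alone, whether the free carboxylic acid itself carries this step remains open, and a methyl ester of the carboxymethyl group, a primary amide or an aminoethyl group at the same position would test that against the ethyl and tert-butyl esters. Going by these compounds, the readings also come from a single dose, so it remains open whether the separation between compound 2 and compound 3 would hold as a difference in potency.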